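The source may hold more compounds than are shown below. What is called first, only, known or untested is meant among the compounds shown, and "the series" means these compounds.

Measured so far:
compound 1, `CCCOC(=O)C1=C(C)NC(=O)NC1c1cccs1`: 32%
compound 2, `CC1=C(C(=O)OCC(C)C)C(c2cccs2)NC(=O)N1`: 11%
compound 3, `CCCOC(=O)C1=C(C)NC(=S)NC1c1ccco1`: 1%

In an assay on membranes from HeLa cells for displacement of a labelled ligand from adenosine receptor A3 (Homo sapiens), read by scintillation counting, with a stated time of 180 min, tested at 1 uM (on this read-out lower numbers stand for less inhibition and higher numbers for more inhibition at the one concentration tested (going by the name of the read-out)), compound 1 gives 32%. Compound 2 shares the core of compound 1 and differs from it by methyl in place of hydrogen on a saturated chain carbon bound to two saturated chain carbons; in this assay compound 2 gives 11%. The step between the two is a number 21 percentage points lower from compound 1 to compound 2 (beyond the scatter). Compound 3 is built on another core; the difference between the two cores is not broken down here. In this assay compound 3 gives 1%, the lowest of the three numbers, though its gap to compound 2 lies within the scatter and only its gap to compound 1 lies beyond it.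

Compound 4, `CC1=C(C(=O)OCC(C)C)C(c2ccco2)NC(=S)N1`, is not yet measured. It stands to compound 3 as compound 2 stands to compound 1, the difference being (methyl in place of hydrogen on a saturated chain carbon bound to two saturated chain carbons). The place of the change is the same word for word in both pairs, so this is the same change, seen twice among the compounds here. Among the measured compounds shown here, its one measured instance points downward and is modest. Because compound 3 gives 1%, there is almost no room for a further fall, so the reading of compound 4 is expected to sit at the foot of the range as well. The expected step is a number 1 percentage points higher from compound 3 to compound 4 (within the scatter), essentially flat. Compound 4 is expected to give 2% in this assay, within the range -8% to 13%.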

Compound 4, a percentage reported as inhibition, at one concentration (the size of the read-out at that concentration, not a potency): 10%
The estimate for compound 4 lay 8 percentage points below the measured number; measured number inside the range.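

In this assay, the change from propoxy to isobutoxy, methyl in place of hydrogen on a saturated chain carbon bound to two saturated chain carbons, does not carry over as a fixed step from one core to the other: the same change on two cores in this assay, a number 21 percentage points lower (beyond the scatter) from compound 1 to compound 2 and a number 9 percentage points higher (within the scatter) from compound 3 to compound 4, 30 percentage points apart, beyond the scatter of two such steps

Taken alone, the new step is a number 9 percentage points higher from compound 3 to compound 4 (within the scatter), so on the core of compound 3 this change gives no reading clear of the scatter, while on the core of compound 1 the step is a number 21 percentage points lower from compound 1 to compound 2 (beyond the scatter). Among the compounds shown here, this rests on only two pairs read at one concentration, so it shows that a step measured on one core is a poor guide to the other, but it does not show which part of the cores makes the difference, nor what the change does to potency.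

The compounds shown hold only propoxy and isobutoxy on the ester, which leaves open how a longer chain such as pentoxy, or a carboxylic acid in place of the ester, would read on either core. Also open, going by these compounds, is how the change would behave on a core that differs from the core of compound 1 in one place only, since that would separate the parts of the two cores.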